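The compounds below may be only part of what the source reports. "The series", "measured", "known", "first", "only" and "open" are said of these compounds alone.

Measured so far:
compound 1 `N/C(=N\NC(=S)N1CCSCC1)c1ccccn1`, 34%
compound 2 `Cc1cccc(/C(N)=N/NC(=S)N2CCCCC2)n1`, 49.9%
compound 3 `Cc1cccc(/C(N)=N/NC(=S)N2CCCC2)n1`, 13.6%

All three were tested in a functional assay on A-375 cells (Homo sapiens) for cytotoxicity, read by MTT assay, with a stated time of 72 h, tested at 1 uM; a lower number here means less inhibition of growth, a higher number more inhibition of growth at the concentration tested. Compound 2 stands highest of the three numbers; compound 1 comes nearest and compound 3 lies furthest off. Among the measured compounds shown here, the one measured step between compounds differing in a single place is a number 36.3 percentage points lower from compound 2 to compound 3 (beyond the scatter), a large drop, but it concerns the ring on the thiocarbonyl carbon, not the part changed here. Compound 4 `N/C(=N\NC(=S)N1CCCCC1)c1ccccn1` differs from compound 2 by hydrogen in place of methyl on an aromatic carbon. For the measured compounds named here, no measured step touches that methyl alone; compound 1, which also lacks it but carries a different ring on the thiocarbonyl carbon, shows a lower number than compound 2. The expected step for compound 4 is therefore a modest decrease, a number 9.9 percentage points lower from compound 2 to compound 4 (within the scatter), perhaps within the scatter. Compound 4 is estimated at 40%, with a range from 25% to 55%.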

Compound 4, percent growth inhibition at one concentration: 72.5%
For compound 4 the middle estimate is 32.5 percentage points below the measured one; measured number above the stated range.
By their numbers in this assay, from the lowest: compound 3; then compound 1; then compound 2; then compound 4.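

In this assay, the methyl next to the ring nitrogen proves not to be needed for growth inhibition: hydrogen in its place gives a number 22.6 percentage points higher from compound 2 to compound 4 (beyond the scatter) and shows that this position affects the result. With hydrogen on that carbon, the ring on the thiocarbonyl carbon also matters, since piperidin-1-yl in place of thiomorpholin-4-yl gives a number 38.5 percentage points higher from compound 1 to compound 4 (beyond the scatter) and the two changes can be compared on the same core. Nothing available explains either step. On these data alone, what an amine or a methoxy group on that aromatic carbon would give stays open, as does whether hydrogen in place of methyl gives a similar step with other rings on the thiocarbonyl carbon.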